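Diastereomer of the nitro compound: expected binding

The compounds below may be only part of what the source reports. "The series", "measured", "known", "first", "only" and "open" are said of these compounds alone.

Two compounds of the series have numbers in an assay on membranes from Cerebral cortex for displacement of a labelled ligand from Neuronal acetylcholine receptor; alpha4/beta2 (Rattus norvegicus), with a stated time of 5 min; a lower number here means a stronger inhibitor, a higher number a weaker inhibitor. Compound 1 `CN1CCC[C@H]1[C@H]1COc2ccc(N)cc2O1` gives 140 nM. Within the data shown here, compound 2 `CN1CCC[C@H]1[C@@H]1COc2ccc([N+](=O)[O-])cc2O1` gives 14000 nM, the higher of the two numbers, with a gap to compound 1 that lies well beyond the scatter; the two compounds differ at both the aromatic substituent and one ring stereocentre, so no single step between them is available.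

Compound 3 `CN1CCC[C@H]1[C@H]1COc2ccc([N+](=O)[O-])cc2O1` differs from compound 2 only in configuration: the two compounds have the same atoms and bonds and differ only in configuration as drawn: 1 of 2 stereo elements differ; a stereocentre at a saturated ring carbon is drawn R in compound 2 and S in compound 3. It carries the configuration drawn for compound 1 together with the nitro group of compound 2.

For compound 3 a lower number than for compound 2 is expected in this assay, because compound 1 with the same ring configuration gives 140 nM while compound 2 gives 14000 nM. The step expected is a 9.3-fold lower number from compound 2 to compound 3 (0.97 log units; beyond the scatter). The estimate for compound 3 is 1500 nM, within 200 nM to 10000 nM.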

Compound 3, inhibition constant: 33000 nM
Compound 3: the middle estimate sits 22-fold (1.34 log units) below what was measured; the whole stated range lies below it.
By their numbers in this assay, from the lowest: compound 1; then compound 2; then compound 3.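

In this assay the change of the ring stereocentre alone gives a 2.4-fold higher number from compound 2 to compound 3 (0.37 log units; beyond the scatter) and so, with the nitro group in place, the configuration drawn for compound 1 carries the higher number. On that same configuration, exchange of the aromatic substituent gives a 240-fold higher number from compound 1 to compound 3 (2.37 log units; beyond the scatter) and this step is far larger than the one at the stereocentre. The first of these steps can be assigned to the stereocentre and to nothing else: the fact that compounds 2 and 3 differ only in the configuration as drawn.

The compounds shown leave open how the amino group behaves on the other configuration, so the stereocentre step is known only with the nitro group. Also open, as far as these compounds go, is whether a methoxy group or an acetamide on the same aromatic carbon would give a number nearer to compound 1 or to compound 3.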